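Changing the Aryl Group on the Chain: Methoxy to Isopropyl

The source may report more compounds than this note shows. Statements on the series, on what has been measured and on what is new or still open speak of the compounds shown alone.

Compound 1, `O=C(COc1ccc(C(=O)/C=C/c2cccc(Cl)c2)cc1)N[C@H]1CCOC1=O`, gives 29100 nM in a functional assay on MGC-803 cells (Homo sapiens) for antiproliferative activity, read by MTT assay, with a stated time of 72 h; a lower number here means a stronger inhibitor, a higher number a weaker inhibitor. Compound 2, `COc1ccccc1/C=C/C(=O)c1ccc(OCC(=O)N[C@H]2CCOC2=O)cc1`, gives 39400 nM in this assay. Compound 3, `CCCCCCCCCCSC(=S)N[C@H]1CCOC1=O`, reaches only a limit of this assay, > 64000 nM, and so no number is known for it.

Among the measured values, compound 2 and compound 1 sit close together: the step of a 1.4-fold higher number from compound 1 to compound 2 (0.13 log units; within the scatter) stays within the usual scatter, so neither can be called the weaker or the stronger of the two. The third value is a limit, as stated by the limit of > 64000 nM in this assay, at which 1 of the 3 values shown sits, and gives no number to compare with.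

Compound 4, `CC(C)c1ccc(/C=C/C(=O)c2ccc(OCC(=O)N[C@H]3CCOC3=O)cc2)cc1`, has not yet been measured. It differs from compound 2 in one place: 4-isopropylphenyl in place of 2-methoxyphenyl on a double-bonded chain carbon bound to a double-bonded chain carbon. Going by the values given here, the only measured step at this same place is the one from compound 1 to compound 2, and that step was within the scatter. On this basis a change of aryl group at this chain position is expected to move this assay little, with no clear direction.

Compound 4 is therefore estimated at about 36000 nM, within a range of 12000 nM to 90000 nM. The step this estimate means, a 1.1-fold lower number from compound 2 to compound 4 (0.04 log units; within the scatter), is expected to stay within the usual scatter.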

Compound 4, half-maximal inhibitory concentration: 16800 nM
Estimate against measurement, compound 4: 2.1-fold (0.33 log units) above; the measured number falls inside the stated range.
By their numbers in this assay, from the lowest: compounds 4, 1 and 2 (each within the scatter of the next, the first and the last beyond it). At a limit, above all of these: compound 3.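

The earlier pair left open whether the aryl group at this place matters at all, and the new result gives the first sign that it can: in this assay the switch to 4-isopropylphenyl gives a 2.3-fold lower number from compound 2 to compound 4 (0.37 log units; beyond the scatter), a modest step but one that clears the scatter. The comparison with the chlorinated compound is less clear, since a 1.7-fold lower number from compound 1 to compound 4 (0.24 log units; within the scatter) stays within the scatter, so compound 4 separates from compound 2 only and cannot be ranked against compound 1. The change replaces a group with one hydrogen-bond acceptor by a group with none and also moves the substituent on the ring, and nothing available here explains the step.

The compounds shown do not separate the identity of the substituent from its place on the ring, which 4-methoxyphenyl or 2-isopropylphenyl at this place on the chain could address. As far as these compounds go, it also remains open how an aryl group carrying an amine or a carboxylic acid would behave here.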